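The compounds below may be only part of what the source reports. "The series", "measured", "known", "first", "only" and "open" are said of these compounds alone.

Measured so far:
- Compound 1 `CC(C)=CC(=O)Nc1cccc(Oc2nc(Nc3ccn(C)n3)nc3c2CSCC3)c1`: > 50000 nM
- Compound 2 `CCC/C=C/C(=O)Nc1cccc(Oc2nc(Nc3ccc(OC)nc3)nc3c2CSCC3)c1`: 26800 nM

Among the measured compounds shown here, in a functional assay on MCF7 cells (Homo sapiens) for antiproliferative activity, read by MTT assay, with a stated time of 72 h (a higher number here means a weaker inhibitor, a lower number a stronger inhibitor), compound 2 gives 26800 nM, the only actual number so far. Compound 1 gives > 50000 nM, which is a limit of this assay and not a number.

The next compound to be tested is compound 3 `COc1ccc(Nc2nc3c(c(Oc4cccc(NC(=O)C=C(C)C)c4)n2)CSCC3)cn1`. It differs from compound 2 in one place: 2-methylprop-1-en-1-yl in place of pent-1-en-1-yl on a carbonyl carbon. In words, 2-methylprop-1-en-1-yl stands in place of pent-1-en-1-yl on a carbonyl carbon, and the rest of the structure is unchanged.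

For the measured compounds named here, no measured pair in this assay shows this change, so its size has to be estimated without a direct precedent. With compound 2 at 26800 nM as the only numerical anchor, no change beyond the usual scatter is expected, and no firm direction can be assigned. The expected move is a 1.1-fold higher number from compound 2 to compound 3 (0.05 log units; within the scatter), which remains an estimate. A result reported only as a limit would not be a surprise.

For compound 3 the estimated value is 30000 nM, with an expected range of 12000 nM to 50000 nM.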

Compound 3, half-maximal inhibitory concentration: 22200 nM
Compound 3: middle estimate off by 1.4-fold (0.13 log units), on the high side, and the stated range covers the measured number.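

In this assay, 2-methylprop-1-en-1-yl in place of pent-1-en-1-yl on the carbonyl carbon gives a 1.2-fold lower number from compound 2 to compound 3 (0.08 log units; within the scatter), so this pair does not separate the two chains at this position when 6-methoxypyridin-3-yl is held constant. Among the compounds shown here, with 2-methylprop-1-en-1-yl held constant, 6-methoxypyridin-3-yl in place of 1-methyl-1H-pyrazol-3-yl on the nitrogen on an aromatic ring gives an at least 2.2-fold lower number from compound 1 to compound 3 (0.35 log units; beyond the scatter), the first step that lies beyond the scatter, which places the only readable shift at this nitrogen and not on the carbonyl carbon. Compound 1 gives > 50000 nM, a limit of the assay and not a number, so the step from it has a minimum size but no upper bound: the limit of > 50000 nM in this assay, at which 1 of the 3 values shown sits.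

From the compounds shown here alone, whether a substituent of another kind on the carbonyl carbon, such as a saturated longer chain or a chain ending in a tertiary amine, would separate from the two alkenyl groups remains open. Also open, going by these compounds, is whether the shift at the nitrogen carries over when pent-1-en-1-yl sits on the carbonyl carbon, and whether a carboxylic acid on the aromatic ring attached to that nitrogen would change the read-out.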